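Ester variation on the shared core: compound 3 to compound 4

The source may hold more compounds than are shown below. What is called first, only, known or untested is meant among the compounds shown, and "the series" means these compounds.

Compound 3 `COc1cc(C2Oc3cc([C@H]4Oc5cc(O)cc(O)c5C(=O)[C@@H]4O)ccc3OC2COC(=O)c2cc(N)cc([N+](=O)[O-])c2)ccc1O` carries a 3-amino-5-nitrophenyl on a carbonyl carbon of the ester arm of the shared core. In a functional assay, read by spectrophotometry, with a stated time of 30 min (on this read-out higher numbers stand for an effect only at larger amounts of compound and lower numbers for an effect already at smaller amounts), compound 3 reaches only the limit of the assay, > 300000 nM. In this assay compound 1 `CCOC(=O)CC(=O)OCC1Oc2ccc([C@H]3Oc4cc(O)cc(O)c4C(=O)[C@@H]3O)cc2OC1c1ccc(O)c(OC)c1` gives 101000 nM, and compound 2 `COc1cc(C2Oc3cc([C@H]4Oc5cc(O)cc(O)c5C(=O)[C@@H]4O)ccc3OC2COC(=O)c2ccc(N)cc2)ccc1O` gives 128000 nM. The step of a 1.3-fold higher number from compound 1 to compound 2 (0.10 log units; within the scatter) is within the scatter, whereas an at least 2.9-fold higher number from compound 1 to compound 3 (0.47 log units; beyond the scatter) and an at least 2.3-fold higher number from compound 2 to compound 3 (0.36 log units; beyond the scatter) both lie beyond it, so compound 3 stands as the weakest of the three, its value sitting at the limit of > 300000 nM in this assay, at which 1 of the 3 values shown sits. Compound 4 `COc1cc(C2Oc3cc([C@H]4Oc5cc(O)cc(O)c5C(=O)[C@@H]4O)ccc3OC2COC(=O)/C=C/c2ccc(Cl)cc2)ccc1O` is not yet measured. The change from compound 3 is 2-(4-chlorophenyl)ethenyl in place of 3-amino-5-nitrophenyl on a carbonyl carbon. Among the measured compounds shown here, both measured steps into compound 3 went to a higher number, and the group that leaves here is the very group that entered in those steps; the group that enters, 2-(4-chlorophenyl)ethenyl, has no counterpart among compounds 1 and 2. The expectation is therefore a return toward the numbers of compound 1 and compound 2 rather than a further rise: for compound 4 the expected step is an at least 1.6-fold lower number from compound 3 to compound 4 (0.22 log units; that floor lies within the scatter), toward a lower number. Compound 4 is estimated at 180000 nM, between 70000 nM and 450000 nM.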

Compound 4, half-maximal effective concentration: 87900 nM
Beside the measured number, compound 4's estimate is 2.0-fold (0.31 log units) above it; low and high end bracket the measured number.
By their numbers in this assay, from the lowest: compounds 4, 1 and 2 (each within the scatter of the next). At a limit, above all of these: compound 3.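

In this assay, an at least 3.4-fold lower number from compound 3 to compound 4 (0.53 log units; beyond the scatter), so the change at this carbonyl carbon is not one-way: replacing 3-amino-5-nitrophenyl with 2-(4-chlorophenyl)ethenyl, which carries no hydrogen-bond donor or acceptor, leaves the limit behind. The value of compound 3 is a limit of the assay and not a number, so this step gives only a floor: the limit of > 300000 nM in this assay, at which 1 of the 4 values shown sits.

Among the compounds shown here, both a 1.5-fold lower number from compound 2 to compound 4 (0.16 log units; within the scatter) and a 1.1-fold lower number from compound 1 to compound 4 (0.06 log units; within the scatter) lie within the scatter, so at this place 2-(4-chlorophenyl)ethenyl, 4-aminophenyl and (ethoxycarbonyl)methyl cannot be told apart, and compound 3 is the one compound that goes against this.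

Going by these compounds, it remains open whether the limit of compound 3 goes with the nitro group, the amino group or their combination, as would be tested by a 3-nitrophenyl or a 3-aminophenyl on the same carbonyl carbon. On these data alone, it is equally open whether the ester link matters, for instance whether an amide in its place, or a phenylethenyl group without the chlorine, would stay in the range of compounds 1, 2 and 4.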